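The compounds below may be only part of what the source reports. "The series", "measured", "known", "first", "only" and "open" are said of these compounds alone.

Measured so far in this series:

compound 1, `CC1=C(C(=O)Nc2ccc([N+](=O)[O-])cc2)C(c2ccc(Br)cc2)N=C(SCc2cccc(Cl)c2)N1` — 9.3%
compound 2, `CC1=C(C(=O)Nc2ccc([N+](=O)[O-])cc2)C(c2ccc(Br)cc2)N=C(SCc2ccc(Cl)cc2)N1` — 19.1%

The read-out is a functional assay on the whole organism (artery, strain albino) with Rattus norvegicus as the target, with a stated time of 180 min, at a dose of 10 mg/kg by the oral route; on this read-out lower numbers stand for less inhibition and higher numbers for more inhibition at the one dose given (going by the name of the read-out). Compound 2 stands highest of the two numbers; the nearest is compound 1, and the step of a number 9.8 percentage points higher from compound 1 to compound 2 (within the scatter) lies within the scatter, so no order between the two is claimed, only that both sit at the low end of the scale.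

Compound 3 `CC1=C(C(=O)Nc2ccc([N+](=O)[O-])cc2)C(c2ccc(Br)cc2)N=C(SCc2ccc(F)cc2)N1` is not yet measured. It differs from compound 2 by fluoro in place of chloro on an aromatic carbon. Going by the values given here, no measured step exchanges one halogen for another on this ring; the single measured step, a number 9.8 percentage points higher from compound 1 to compound 2 (within the scatter), reads 4-chlorophenyl in place of 3-chlorophenyl and lies within the scatter. Among the compounds with values here, nothing among the measured pairs therefore argues for a move beyond the scatter in this assay, in either direction. The step expected for compound 3 is a number 4.1 percentage points lower from compound 2 to compound 3 (within the scatter), small and without a clear direction. Compound 3 is accordingly estimated at 15%, with a range from 3% to 30%.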

Compound 3, a percentage reported as inhibition, in the whole organism at one dose (the size of the read-out at that dose, not a potency): 17.5%
Estimate against measurement, compound 3: 2.5 percentage points below; measured number inside the range.
By their numbers in this assay, from the lowest: compounds 1, 3 and 2 (each within the scatter of the next).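

In this assay, the exchange of one halogen for another on this ring gives a number 1.6 percentage points lower from compound 2 to compound 3 (within the scatter), so 4-fluorobenzyl and 4-chlorobenzyl on the sulfur cannot be told apart at the one dose given. Set against the 3-chlorophenyl compound, the 4-fluorophenyl compound gives a number 8.2 percentage points higher from compound 1 to compound 3 (within the scatter), so all three compounds now lie within the scatter of one another and none of these halogen exchanges on the benzyl group separates them. No measured evidence on these compounds speaks to what lies behind this result.

Still open, on these data alone, is whether a methoxy group, an amine or a carboxylic acid in place of the halogen on this ring, or a longer chain in place of the benzyl group on the sulfur, would move the number in this assay beyond the scatter, or whether this end of the molecule has little bearing on the read-out at this dose. As far as these compounds go, the bromophenyl and nitrophenyl groups are shared by all three compounds, so what each of them contributes also stays open.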